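Working notes: 3-methyl-1H-1,2,4-triazol-1-yl for 1H-imidazol-1-yl

The source may hold more compounds than are shown below. What is called first, only, known or untested is meant among the compounds shown, and "the series" means these compounds.

In an ADME assay on microsomes from liver (Rattus norvegicus) for metabolic stability (on this read-out lower numbers stand for slow clearance and higher numbers for fast clearance), compound 1 `CNc1nc(NC2(C#N)CCCCC2)nc(-n2ccnc2)n1` gives 52 mL/min/kg as its measured value, and compound 2 `CNc1nc(NC2(C#N)CCCCC2C)nc(-n2cncn2)n1` gives 86 mL/min/kg as its measured value. The two numbers lie within the scatter of each other, so compound 1 holds no separate place among the data so far.

Compound 3 `CNc1nc(NC2(C#N)CCCCC2)nc(-n2cnc(C)n2)n1`, not yet measured, comes from compound 1 by putting 3-methyl-1H-1,2,4-triazol-1-yl in place of 1H-imidazol-1-yl on an aromatic carbon while the methylamino group stays as it is. For the measured compounds named here, no measured pair isolates this change, so the data give no direct size for it. Going by the values given here, the expectation therefore rests on compound 1 at 52 mL/min/kg as the starting point and on compound 2 at 86 mL/min/kg as the only other reading. In this assay no step beyond the scatter is expected in either direction. The estimated step of a 1.2-fold higher number from compound 1 to compound 3 (0.06 log units; within the scatter) stays within the scatter of repeat measurements. For compound 3 the expected clearance is 60 mL/min/kg with an estimated range from 30 mL/min/kg to 115 mL/min/kg on repeat measurement.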

Compound 3, clearance: > 276 mL/min/kg
Compound 3 was reported as a limit; the forecaster's own chance of this, stated with the estimate: 2%; middle value at least 4.6-fold (0.66 log units) from the limit.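

Working notes on the position opposite the ring nitrogen: 3-methyl-1H-1,2,4-triazol-1-yl in place of 1H-imidazol-1-yl gives an at least 5.3-fold higher number from compound 1 to compound 3 (0.72 log units; beyond the scatter) in this assay, the first step in the series that isolates a single place. For the compounds shown here, the group on this aromatic carbon therefore matters for clearance in the context of compound 1, with the methylamino group and the rest of the core unchanged, and the step lies beyond the scatter, which no earlier pair could show for this position. The reading of compound 3 is a limit of the assay and not a number, so the step gives only a lower bound on the size of this change: the limit of > 276 mL/min/kg in this assay, at which 1 of the 3 values shown sits.

Open, from the compounds shown here alone, is which part of the exchange carries the step, the extra ring nitrogen or the methyl group, as the two enter together in compound 3. Also open, going by these compounds, is how a different kind of group at this place, such as a dimethylamino group or a carboxylic acid, would read in this assay on the core of compound 1.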